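The source may hold more compounds than are shown below. What is called first, only, known or untested is meant among the compounds shown, and "the series" means these compounds.

Compound 1, `Clc1ccncc1C1=CC2CNCC(C1)C2`, binds in an in vitro assay on SH-EP1 cells for displacement of a labelled ligand from Neuronal acetylcholine receptor; alpha4/beta2 (Homo sapiens) (on this read-out lower numbers stand for stronger inhibition and higher numbers for weaker inhibition), with a value of 3 nM. Among the three compounds measured so far it holds the second highest number: compound 3, `C1=C(c2cncc(OCc3ccccc3)c2)CC2CNCC1C2`, gives 0.7 nM, a lower number than compound 1, while compound 2, `CN1CC2C=C(c3cnccc3Cl)CC(C2)C1`, gives 1160 nM, much the highest. For the measured compounds named here, the only single change measured so far is a 390-fold higher number from compound 1 to compound 2 (2.59 log units; beyond the scatter), which shows how sharply this read-out can move when the amine nitrogen of the shared core is altered. Compound 4, `C1=C(c2cccnc2)CC2CNCC1C2`, differs from compound 1 elsewhere: hydrogen in place of chloro on an aromatic carbon. Going by the values given here, no measured step touches this position, so nothing directly tells how much the chloro contributes; compound 3 carries its own group on a different ring position and does not settle the question. With the core and the amine untouched, and compounds 1 and 3 both giving low numbers, only a modest shift, if any beyond the scatter, is expected. Compound 4 is therefore estimated at 2 nM, with a likely range from 0.5 nM to 10 nM. This expected change amounts to a 1.5-fold lower number from compound 1 to compound 4 (0.18 log units; within the scatter).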

Compound 4, inhibition constant: 0.2 nM
Compound 4: the middle estimate sits 10-fold (1.00 log units) above what was measured, outside the stated range (below it).
By their numbers in this assay, from the lowest: compound 4; then compound 3; then compound 1; then compound 2.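

Replacing the chloro with hydrogen gives a 15-fold lower number from compound 1 to compound 4 (1.18 log units; beyond the scatter), so this place on the aromatic ring, opposite the ring nitrogen, clearly affects the read-out. The earlier compounds shown here could not show this, as none of their measured steps touched this position. In this pair, the chloro is not needed for a low number, and its presence goes with a higher one, but nothing available explains the size of this step.

Still open, from the compounds shown here alone, is how other groups at this same place, such as fluoro, methyl, methoxy or an amine, would compare with chloro and hydrogen. Also open, going by these compounds, is whether the same swap would shift the number as far in a compound with a methyl on the amine nitrogen, such as compound 2.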